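The compounds below may be only part of what the source reports. "The series", "measured", "known", "first", "only" and "open" are said of these compounds alone.

Measured so far in the series:

- compound 1, `ClCc1ccccc1Cn1cnc2c(Cl)ncnc21` — 5880 nM
- compound 2, `ClCc1cccc(Cn2cnc3ncnc(Cl)c32)c1` — 45700 nM
- compound 3, `ClCc1cccc(Cn2cnc3c(Cl)ncnc32)c1` — 24600 nM

All three numbers come from a functional assay on SK-MEL-5 cells (Homo sapiens) for cytotoxicity, read by sulforhodamine B assay, with a stated time of 48 h; on this read-out lower numbers stand for higher toxicity in this test and higher numbers for lower toxicity in this test. Among them compound 3 has the second highest number. Its nearest neighbour is compound 2, whose number is higher by an amount that lies within the scatter, so the two cannot be ordered; its furthest is compound 1, whose number is lower by an amount beyond the scatter. No pair of these compounds differs in a single place, so no step between measured compounds can be read off.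

The next compound, compound 4, `ClCc1cccc(Cn2cnc3c(Cl)nc(Cl)nc32)c1`, is the unmeasured one. It is derived from compound 3 by one change: chloro in place of hydrogen on an aromatic carbon. For the measured compounds named here, nothing among the measured compounds shows what a second chloro on the core does in this assay, so the direction is not anchored by data. A step of modest size is expected, not confidently beyond the scatter, with a slight lean towards a lower number; the expected step is a 1.6-fold lower number from compound 3 to compound 4 (0.21 log units; within the scatter). On that basis compound 4 is estimated at 15000 nM in this assay, with the likely range running from 4000 nM to 60000 nM.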

Compound 4, concentration lethal to 50% of the cells: 5880 nM
Compound 4: the middle estimate sits 2.6-fold (0.41 log units) above what was measured, and the stated range covers the measured number.
By their numbers in this assay, from the lowest: compounds 1 and 4 (each within the scatter of the next); then compounds 3 and 2 (each within the scatter of the next).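

In this assay the chloro on the aromatic carbon between two ring nitrogen atoms gives a 4.2-fold lower number from compound 3 to compound 4 (0.62 log units; beyond the scatter) and this step lies beyond the scatter. For the compounds shown here, this is the first change that can be read in a single place, and it shows that this position is not silent in this read-out: with chloro in place of hydrogen, the number moves towards higher toxicity in this test. No measurement shown here accounts for the step, so it stands as an observation without an explanation.

From the compounds shown here alone, the reading rests on one pair and one substituent, so it remains open whether the same change on compound 1 or compound 2 would give a step of similar size and direction. Going by these compounds, it is also open whether the step is particular to chloro or would also appear with an amine, a methoxy group or a methyl group on the same carbon.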